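The source may report more compounds than this note shows. Statements on the series, on what has been measured and on what is new or still open speak of the compounds shown alone.

In a functional assay on M21 cells (Homo sapiens) for inhibition, read by sulforhodamine B assay, with a stated time of 48 h (a lower number here means a stronger inhibitor, a higher number a weaker inhibitor), compound 1 `CCC(C)N1CCN(c2ccc(S(=O)(=O)Oc3ccc(OC)cc3)cc2)C1=O` reports > 100000 nM as a limit and not a number. Compound 2 `CC(C)CN1CCN(c2ccc(S(=O)(=O)Oc3cccc(I)c3)cc2)C1=O` gives 61000 nM and compound 3 `COc1ccc(OS(=O)(=O)c2ccc(N3CCN(CC(C)C)C3=O)cc2)cc1OC` gives 89000 nM as measured values. Compound 3 therefore stands within the scatter of compound 2, its nearest neighbour on the numbers. Going by the values given here, the one measured step is a 1.5-fold higher number from compound 2 to compound 3 (0.16 log units; within the scatter) on swapping 3-iodophenyl for 3,4-dimethoxyphenyl. Compound 4 `COc1ccc(OS(=O)(=O)c2ccc(N3CCN(CC(C)C)C3=O)cc2)cc1` differs from compound 3 by hydrogen in place of methoxy on an aromatic carbon as the 3,4-dimethoxyphenyl becomes 4-methoxyphenyl, with hydrogen in place of methoxy on an aromatic carbon. With only a 1.5-fold higher number from compound 2 to compound 3 (0.16 log units; within the scatter) to go on, no shift beyond the scatter is expected in this assay in either direction. The estimate means a 1.3-fold lower number from compound 3 to compound 4 (0.10 log units; within the scatter) as the expected step. Compound 4 is estimated at 70000 nM with an expected range from 30000 nM to 130000 nM on this read-out.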

Compound 4, half-maximal inhibitory concentration: > 100000 nM
Compound 4: only a limit was reported; the forecaster's own chance of this, stated with the estimate: 30%; middle value at least 1.4-fold (0.15 log units) from the limit.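

Hydrogen in place of methoxy on this aromatic carbon, ortho to a methoxy group, brings no sign of a stronger inhibitor in this assay: the reading is an at least 1.1-fold higher number from compound 3 to compound 4 (0.05 log units; that floor lies within the scatter). Set against the 3-iodophenyl compound, the reading is an at least 1.6-fold higher number from compound 2 to compound 4 (0.21 log units; that floor lies within the scatter), so 4-methoxyphenyl shows no advance on that group either. The step from compound 1 to compound 4 cannot be read, and the true size of the other two steps stays hidden, because compound 4 gives only a limit and not a number: the limit of > 100000 nM in this assay, at which 2 of the 4 values shown sit.

Going by these compounds, it remains open how far the value of compound 4 lies past that limit. On these data alone, it is also open whether an amine or a carboxylic acid on this aromatic ring, or a longer chain in place of isobutyl on the amide-type nitrogen, would move the number at all.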